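The source may hold more compounds than are shown below. What is called first, only, known or untested is meant among the compounds shown, and "the series" means these compounds.

In a toxicity assay on HEK293 cells (Homo sapiens) for inhibition, read by resazurin assay, with a stated time of 24 h (a lower number here means that less compound is tolerated, a higher number that more compound is tolerated), compound 1 (`Cn1c([N+](=O)[O-])cnc1C(=O)NCc1ccccn1`) gives > 100000 nM, which is a limit and not a number. Compound 2 (`NC(=O)c1nc([N+](=O)[O-])cn1Cc1ccc(F)cc1`) gives > 100000 nM, also a limit. Compound 3 (`NC(=O)c1nc([N+](=O)[O-])cn1Cc1ccc(OC(F)(F)F)cc1`) gives > 100000 nM, again only a limit. The whole set therefore stands together, with the limit of > 100000 nM in this assay, at which 3 of the 3 values shown sit. Compound 4 (`O=C(NO)c1nc([N+](=O)[O-])cn1Cc1ccc(OC(F)(F)F)cc1`) has hydroxy in place of hydrogen on an amide-type nitrogen of compound 3: hydroxy in place of hydrogen on an amide-type nitrogen. Going by the values given here, the only measured step, a step that the two limits leave unreadable from compound 2 to compound 3, involves a different change and offers no size to carry over. Any expectation in this assay is therefore loose, with a small move towards less tolerated compound as the cautious guess. The expected change is an at least 1.2-fold lower number from compound 3 to compound 4 (0.09 log units; that floor lies within the scatter). For compound 4, the estimated value is 80000 nM, with an expected range of 20000 nM to 200000 nM.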

Compound 4, half-maximal cytotoxic concentration: 36000 nM
Beside the measured number, compound 4's estimate is 2.2-fold (0.35 log units) above it; the measured number falls inside the stated range.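

Hydroxy in place of hydrogen on the amide-type nitrogen gives an at least 2.7-fold lower number from compound 3 to compound 4 (0.44 log units; beyond the scatter) in this assay, so carbamoyl to hydroxycarbamoyl is a change that registers in this assay. Going by these compounds alone, the one earlier step, on the aromatic carbon, cannot be read. Compound 4 is thus the only compound here with a number and not a limit: the limit of > 100000 nM in this assay, at which 3 of the 4 values shown sit.

The compounds shown leave open whether a methyl or a methoxy on that nitrogen would lower the number in the same way. They also leave open whether hydroxy on that nitrogen of compound 2 would give a step of similar size.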